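A few compounds are considered here, and "the series" means these few. Any claim that something is new, unique, unknown or untested is made for them only; others in the source may bear on it.

Compound 1 `COc1cc(C)cc(-c2c(-c3ccnc(-c4ccc(C(C)=O)cc4)c3)cnn2CC#N)c1` was tested in a functional assay on SNB-19 cells (Homo sapiens) for cytotoxicity, read by sulforhodamine B assay, with a stated time of 48 h, tested at 0.001 uM (a higher number here means a weaker effect of the compound at the concentration tested, a lower number a stronger effect), where compound 1 gives 102%. Compound 2 `Cc1cc(O)cc(-c2nn(CC#N)cc2-c2ccnc(-c3ccc(Oc4ccccc4)cc3)c2)c1` lies within the usual scatter of that result, since in this assay compound 2 gives 101%; neither compound shows an effect at this concentration. Compound 3 `COc1cc(C)cc(-c2c(-c3ccnc(-c4ccc(N(C)C)cc4)c3)cnn2CC#N)c1` has not yet been measured. It differs from compound 1 in one place: dimethylamino in place of acetyl on an aromatic carbon. Going by the values given here, with no measured step to lean on, no change beyond the scatter is expected. For compound 3 the expected value is 100%, with a range from 90% to 110%. The expected step is a number 2 percentage points lower from compound 1 to compound 3 (within the scatter), essentially none.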

Compound 3, a percentage reported as activity, at one concentration (the size of the read-out at that concentration, not a potency): 90%
For compound 3 the middle estimate is 10 percentage points above the measured one, within the range that was stated.
By their numbers in this assay, from the lowest: compound 3; then compounds 2 and 1 (each within the scatter of the next).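

The read-out in this assay comes out a number 12 percentage points lower from compound 1 to compound 3 (beyond the scatter) when 4-(dimethylamino)phenyl replaces 4-acetylphenyl. This shows that a change at this aromatic carbon, para to a large group, can shift the result even at this low concentration, although the group that leaves and the group that enters have the same number of heavy atoms. Nothing available here accounts for the shift. On these data alone, whether a plain amino group or a carboxylic acid at this place would lower the number further remains open, as does whether the step would hold at other concentrations.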